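From a Nitrophenyl to a Methoxyphenyl on the Ring Nitrogen

This account rests on a few compounds, and the source may have more. Where it says the series, first, only, none or still open, it means among the compounds named here.

Three amides of a shared core, compound 1 `CCN1CCN(CC(=O)Nc2nc3ccccc3[nH]2)CC1`, compound 2 `O=C(CN1CCN(c2ccccc2)CC1)Nc1nc2ccccc2[nH]1` and compound 3 `O=C(CN1CCN(c2ccc([N+](=O)[O-])cc2)CC1)Nc1nc2ccccc2[nH]1`, were tested in a functional assay, read by spectrophotometry, with a stated time of 30 min, tested at 5 ug/mL; on this read-out lower numbers stand for a weaker effect and higher numbers for a stronger effect at the one concentration tested. Compound 1 gives 13.3%, compound 2 gives 4.62% and compound 3 gives 16.1%. Compound 3 thus sits at the top of the three numbers, yet a number 2.8 percentage points higher from compound 1 to compound 3 (within the scatter), whereas a number 11.5 percentage points higher from compound 2 to compound 3 (beyond the scatter). Compound 4 `COc1ccccc1N1CCN(CC(=O)Nc2nc3ccccc3[nH]2)CC1` differs from compound 3 in one place: 2-methoxyphenyl in place of 4-nitrophenyl on an amine nitrogen in a ring. Going by the values given here, the steps that bear on this change are a number 11.5 percentage points higher from compound 2 to compound 3 (beyond the scatter), the only one beyond the scatter, and a number 8.7 percentage points lower from compound 1 to compound 2 (within the scatter). Because a number 11.5 percentage points higher from compound 2 to compound 3 (beyond the scatter) was only modest, the step of a number 8.1 percentage points lower from compound 3 to compound 4 (within the scatter) is expected to be no larger than that and most likely downward. Compound 4 is estimated at 8%, within 2% to 16%.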

Compound 4, a percentage reported as activity, at one concentration (the size of the read-out at that concentration, not a potency) in the functional assay: 10.8%
The estimate for compound 4 lay 2.8 percentage points below the measured number; measured number inside the range.
By their numbers in the functional assay, from the lowest: compounds 2, 4, 1 and 3 (each within the scatter of the next, the first and the last beyond it).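

In the functional assay, 2-methoxyphenyl on the amine nitrogen in a ring does not set compound 4 apart from any of the other three: a number 5.3 percentage points lower from compound 3 to compound 4 (within the scatter), a number 6.2 percentage points higher from compound 2 to compound 4 (within the scatter) and a number 2.5 percentage points lower from compound 1 to compound 4 (within the scatter). Compound 4 thus lies within the scatter of both compound 2 and compound 3, the two compounds that differ beyond it. Yet the exchange of 4-nitrophenyl for 2-methoxyphenyl does separate two compounds in lipophilicity in a physicochemical assay for lipophilicity, read by spectrophotometry, using the shake flask method, measured as octanol-water partition, with a stated time of 24 h; on this read-out higher numbers stand for higher lipophilicity and lower numbers for lower lipophilicity: the measured partition coefficient of compound 3, 1.94, and of compound 4, 0.97, a number 0.97 log units lower (beyond the scatter) In the physicochemical assay compound 3 gives 1.94 and compound 4 gives 0.97 as partition coefficients.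

Still open, from the compounds shown here alone, is whether an amine or a carboxylic acid on the phenyl ring would carry the number in the functional assay beyond the scatter from compound 4.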